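Maximal response in the series: step from compound 3 to compound 4

This account rests on a few compounds, and the source may have more. Where it says the series, first, only, none or still open, it means among the compounds named here.

Measured so far:
compound 1, `Cc1c(OCCCCOc2ccc(C(=O)CC(C)(C)C)c(O)c2C)cccc1C(=O)O`, 109%
compound 2, `Cc1c(OCCCCOc2cccc(C(=O)O)c2)ccc(C(=O)CC(C)C)c1C`, 18.3%
compound 3, `CCCC(=O)c1ccc(OCCCCOc2ccc(C(=O)O)cc2C)c(C)c1O`, 40.5%

In an assay on HEK293 cells for positive allosteric modulation of metabotropic glutamate receptor 3 (Rattus norvegicus), read by thallium flux, with a stated time of 2.5 min (a higher number here means a larger maximal response, a lower number a smaller maximal response), compound 1 gives 109%, compound 2 gives 18.3% and compound 3 gives 40.5%. Compound 3 stands second highest of the three numbers; its nearest neighbour is compound 2, lower by a gap beyond the scatter, and its furthest is compound 1, higher by a gap well beyond the scatter. Among the measured compounds shown here, compounds 1 and 2 differ from compound 3 in more than one place, so no single-point step between measured compounds is available.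

Compound 4, `Cc1cc(C(=O)O)ccc1OCCCCOc1ccc(C(=O)CC2CCCC2)c(O)c1C`, is not yet measured. It differs from compound 3 as follows: cyclopentyl in place of ethyl on a saturated chain carbon bound to a carbonyl carbon. Read one bond further out, propylcarbonyl becomes (cyclopentylmethyl)carbonyl.

For the measured compounds named here, no measured pair informs this change directly. The expectation for compound 4 in this assay is a modest step upward, possibly no larger than the scatter, as a number 14.5 percentage points higher from compound 3 to compound 4 (beyond the scatter). Compound 4 is therefore estimated at 55%, with a range from 20% to 95%.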

Compound 4, largest response reached (reported as percent of maximum), in percent of the reference or control that the assay uses: 28.4%
Estimate against measurement, compound 4: 26.6 percentage points above, within the range that was stated.
By their numbers in this assay, from the lowest: compound 2; then compound 4; then compound 3; then compound 1.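

In this assay, among the compounds shown here, cyclopentyl in place of ethyl on a saturated chain carbon bound to a carbonyl carbon gives a number 12.1 percentage points lower from compound 3 to compound 4 (beyond the scatter) and provides the first single-place step. At this position, the larger group of 5 heavy atoms, with its five-membered ring of carbon only, therefore lowers the maximal response relative to the 2 heavy atoms of ethyl, although it does not abolish that response. No measurement at hand gives a reason for this step.

A single step cannot separate the ring itself from the added carbon count as the feature that goes with the drop. As far as these compounds go, how cyclohexyl, an open longer chain of similar size, or an amine at this same place would read remains open.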